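Methoxy to ethoxy on the acyl ring of compound 1

The compounds below may be only part of what the source reports. "The series", "measured", "known", "first", "only" and "open" are said of these compounds alone.

Among the compounds with values here, compound 1 `COc1ccc(OC)c(C(=O)/C=C/c2ccc(O)c(O)c2)c1` gives 7.8 nM in an assay on RBL-1 cells for inhibition of Polyunsaturated fatty acid 5-lipoxygenase (Rattus norvegicus) (on this read-out lower numbers stand for stronger inhibition and higher numbers for weaker inhibition), the lowest of the three numbers measured so far. Compound 2 `COc1ccc(C(=O)/C=C/c2ccc(O)c(O)c2)cc1OC` gives 18 nM in this assay, and compound 3 `COc1cc(C(=O)/C=C/c2ccc(O)c(O)c2)cc(OC)c1OC` gives 16 nM; both numbers stand beyond the scatter from that of compound 1, compound 3 being the nearer of the two. Within the data shown here, the only single-point step among the measured compounds is a 1.1-fold lower number from compound 2 to compound 3 (0.05 log units; within the scatter), so a methoxy added on an aromatic carbon left the number within the scatter.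

Compound 4 `CCOc1ccc(OC)c(C(=O)/C=C/c2ccc(O)c(O)c2)c1` differs from compound 1 by methyl in place of hydrogen on a saturated chain carbon bound to an oxygen on an aromatic ring; read one bond further out, this is methyl to ethyl, methoxy to ethoxy. Among the measured compounds shown here, no measured step touches this saturated chain carbon, and the one step available, itself within the scatter, concerns the ring only. On that basis the expected step in this assay is a 1.2-fold higher number from compound 1 to compound 4 (0.06 log units; within the scatter), none beyond the scatter in either direction. Compound 4 is therefore estimated at 9 nM in this assay, between 4 nM and 25 nM.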

Compound 4, half-maximal inhibitory concentration: 3.8 nM
Compound 4: the middle estimate sits 2.4-fold (0.37 log units) above what was measured; the measured number lies below the stated range.
By their numbers in this assay, from the lowest: compound 4; then compound 1; then compounds 3 and 2 (each within the scatter of the next).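

Methoxy to ethoxy gives a 2.1-fold lower number from compound 1 to compound 4 (0.31 log units; beyond the scatter) in this assay, which makes compound 4 the lowest number in the set. Within the data shown here, this is the first measured change on a saturated chain carbon bound to an oxygen on an aromatic ring, and it shows that the number responds to a single added methyl at this place, whereas the only earlier single-point step, a 1.1-fold lower number from compound 2 to compound 3 (0.05 log units; within the scatter), concerned an aromatic carbon and stayed within the scatter. No measurement at hand offers an explanation for the step.

From the compounds shown here alone, it remains open whether a propoxy or a longer chain on this oxygen would lower the number further or raise it again. Also open, going by these compounds, is whether the other methoxy of compound 1, or the methoxy groups of compound 2 and compound 3, would respond in the same way to ethoxy.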